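The compounds below may be only part of what the source reports. "The series", "measured", "known", "first", "only" and "open" are said of these compounds alone.

Going by the values given here, compound 2 `Cc1cccc(NC(=O)c2cccc(OS(C)(=O)=O)c2)n1` holds the highest number of the two so far in an assay on membranes from brain for binding affinity to metabotropic glutamate receptor 5 (Rattus norvegicus) (a higher number here means a weaker inhibitor, a lower number a stronger inhibitor), where compound 2 gives 83600 nM. Among the compounds with values here, its only measured neighbour is compound 1 `Cc1cccc(C(=O)Nc2cccc(C)n2)c1`, which in this assay gives 1840 nM; the one step joining them, a 45-fold higher number from compound 1 to compound 2 (1.66 log units; beyond the scatter), is the only step available and it is large. Compound 3 `Cc1cccc(NC(=O)c2cccc(C#N)c2)n1` keeps the shared core of compound 2 and differs from it at one site: cyano in place of (methylsulfonyl)oxy on an aromatic carbon. Within the data shown here, no measured pair shows a cyano entering, so the data bear only indirectly: the step of a 45-fold higher number from compound 1 to compound 2 (1.66 log units; beyond the scatter) shows that putting (methylsulfonyl)oxy on this aromatic carbon in place of methyl went with a much higher number, and removing that group is the main content of the change to compound 3. Going by these compounds, whether cyano then gives a number close to that of methyl is untested here. The expectation is that the number falls back toward the level of compound 1, so compound 3 is estimated at 1000 nM in this assay, with a range of 200 nM to 8000 nM. That estimate means a step of an 84-fold lower number from compound 2 to compound 3 (1.92 log units; beyond the scatter), expected to be large, downward and beyond the scatter.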

Compound 3, half-maximal inhibitory concentration: 330 nM
For compound 3 the middle estimate is 3.0-fold (0.48 log units) above the measured one; the measured number falls inside the stated range.
By their numbers in this assay, from the lowest: compound 3; then compound 1; then compound 2.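

In this assay, the step of a 250-fold lower number from compound 2 to compound 3 (2.40 log units; beyond the scatter) is larger than the earlier rise a 45-fold higher number from compound 1 to compound 2 (1.66 log units; beyond the scatter), so replacing (methylsulfonyl)oxy on this aromatic carbon, meta to a large group, does more than restore the level of compound 1. The step of a 5.6-fold lower number from compound 1 to compound 3 (0.75 log units; beyond the scatter) adds what the first pair could not show: methyl is not the group with the lowest number at this position, and a modest gain beyond the scatter is available from cyano. Nothing on hand accounts for either step, and the order of the three compounds stands here as an observation only.

Going by these compounds, whether the lower number is particular to cyano or would extend to other groups on this aromatic carbon, such as an amine, a carboxylic acid, a chlorine atom or a longer chain, stays open, as the three compounds give only three points at one site. On these data alone, how far the result carries to other positions also stays open, as all three compounds keep the rest of the shared core unchanged, including the amide and the second methyl group.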